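The source may report more compounds than this note shows. Statements on the series, on what has been measured and on what is new or still open speak of the compounds shown alone.

Of the compounds shown here, two have been measured so far in an ADME assay on microsomes from liver (Mus musculus) for metabolic stability, read by LC-MS, using NADPH, with a stated time of 30 min, tested at 0.1 uM; a higher number here means that more of the compound is left, a lower number that less of the compound is left. Compound 1 `NS(=O)(=O)c1cncc(-c2ccc3nccc(-c4cn[nH]c4)c3n2)c1` gives 2%, and compound 2 `O=S(=O)(c1cccc(-c2ccc3nccc(-c4ccncc4)c3n2)c1)N1CCC(O)CC1` gives 7%. These two numbers lie within the usual scatter of each other, so compound 2 stands level with compound 1, and both sit near the bottom of the scale.

Compound 3 `C[C@@H]1CN(S(=O)(=O)c2cccc(-c3ccc4nccc(-c5ccncc5)c4n3)c2)C[C@H](C)N1` has not yet been measured. It keeps the core of compound 2 and changes one group: 3,5-dimethylpiperazin-1-yl in place of 4-hydroxypiperidin-1-yl on a sulfonyl sulfur. A 3,5-dimethylpiperazin-1-yl group thus replaces the 4-hydroxypiperidin-1-yl group on a sulfonyl sulfur. For the measured compounds named here, no measured pair of compounds differs in just one place, so the data offer no direct guide to the effect of such a swap. With compound 2 at 7%, there is little room for a further fall, and a large rise has no support in the data. No step beyond the scatter is therefore expected in this assay, in either direction. The estimated step of a number 1 percentage points lower from compound 2 to compound 3 (within the scatter) is expected to be small. For compound 3 the estimated value is 6%, with an expected range of 1% to 20%.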

Compound 3, percent of the compound remaining: 33%
For compound 3 the middle estimate is 27 percentage points below the measured one; measured number above the stated range.
By their numbers in this assay, from the lowest: compounds 1 and 2 (each within the scatter of the next); then compound 3.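

In this assay, the group on a sulfonyl sulfur proves able to shift the read-out: 3,5-dimethylpiperazin-1-yl in place of 4-hydroxypiperidin-1-yl gives a number 26 percentage points higher from compound 2 to compound 3 (beyond the scatter). For the compounds shown here, this is the first pair that differs in just one place, so the effect of a change at this position can now be read directly rather than inferred from compounds that differ in several places. Nothing measured here explains the step, so the result records what happens but not why.

The new group differs from the old one in several ways at once, with a second ring nitrogen in place of the ring carbon that carries the hydroxyl, two added methyl groups and two defined stereocentres, and the compounds shown cannot say which of these matters; a plain piperazin-1-yl or a morpholin-4-yl group on the same sulfonyl sulfur would help to separate them. This is also a single pair on a single core, so whether the same swap would give a similar step on another core remains an open question.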